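Dropping a Trifluoromethyl from the Sulfone Aryl Ring

The source may hold more compounds than are shown below. What is called first, only, known or untested is meant among the compounds shown, and "the series" means these compounds.

Compound 1, `O=C(NCc1ccc(S(=O)(=O)c2ccc(F)c(F)c2)cc1)c1cc2cnccc2[nH]1`: 14 nM
Compound 2, `O=C(NCc1ccc(S(=O)(=O)c2ccccc2)cc1)c1cc2ccncc2s1`: 14 nM
Compound 3, `O=C(NCc1ccc(S(=O)(=O)c2cccc(C(F)(F)F)c2)cc1)c1cc2cnccc2[nH]1`: 3 nM

All three were tested in a functional assay on A2780 cells (Homo sapiens) for inhibition, read by sulforhodamine B assay, with a stated time of 72 h; a lower number here means a stronger inhibitor, a higher number a weaker inhibitor. Compound 3 stands lowest of the three numbers; its gaps to compound 1 and to compound 2 are both beyond the scatter, so it can be called the strongest inhibitor of this set.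

Compound 4, `O=C(NCc1ccc(S(=O)(=O)c2ccccc2)cc1)c1cc2cnccc2[nH]1`, differs from compound 3 in one place: hydrogen in place of trifluoromethyl on an aromatic carbon. Going by the values given here, one measured step bears on this change, since it concerns the same ring on the sulfonyl sulfur: a 4.7-fold lower number from compound 1 to compound 3 (0.67 log units; beyond the scatter). Putting the trifluoromethyl group onto that ring thus went with a clearly lower number, and taking it away again is expected to reverse part of that gain. Compound 2 also carries a plain phenyl on the sulfonyl sulfur, though on a different core, and in this assay compound 2 gives 14 nM.

Compound 4 is therefore expected to give a higher number than compound 3, with a step estimated at a 3.3-fold higher number from compound 3 to compound 4 (0.52 log units; beyond the scatter). The estimate for compound 4 is 10 nM, with a likely range from 4 nM to 30 nM.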

Compound 4, half-maximal inhibitory concentration: 18 nM
For compound 4 the middle estimate is 1.8-fold (0.26 log units) below the measured one; the measured number falls inside the stated range.
By their numbers in this assay, from the lowest: compound 3; then compounds 1, 2 and 4 (each within the scatter of the next).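

In this assay, taking the trifluoromethyl off the ring on the sulfonyl sulfur gives a 6.0-fold higher number from compound 3 to compound 4 (0.78 log units; beyond the scatter) on an otherwise unchanged molecule, so this single group now has a direct comparison behind it. Plain phenyl and 3,4-difluorophenyl on that sulfur cannot be told apart, with a 1.3-fold higher number from compound 1 to compound 4 (0.11 log units; within the scatter) and so no visible effect of those two fluorines, and the change of core also stays small, with a 1.3-fold higher number from compound 2 to compound 4 (0.11 log units; within the scatter) for that swap. Nothing available here explains why the trifluoromethyl makes this difference when the fluorines do not.

Still open, as far as these compounds go, is whether trifluoromethyl is special at this carbon, or whether a methyl, a chlorine or a methoxy group there would serve as well. Also open, from the compounds shown here alone, is whether adding trifluoromethyl to the plain phenyl ring of compound 2 would give a similar step on that other core.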